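The source may hold more compounds than are shown below. What is called first, only, known or untested is meant among the compounds shown, and "the series" means these compounds.

Of the compounds shown here, three built on one shared core have been measured, each with a different group hung from the ring nitrogen of a side chain. Compound 1 `CN1CCN(CCCCCCn2c3c(c4ccccc42)C(=O)c2c[n+]([O-])c4ccccc4c2C3=O)CC1` gives 2400 nM in a functional assay on MDA-MB-231 cells (Homo sapiens) for cytotoxicity, read by MTT assay, with a stated time of 72 h; a lower number here means a stronger inhibitor, a higher number a weaker inhibitor. Compound 2 `CC1(C)OCC(Cn2cc(Cn3c4c(c5ccccc53)C(=O)c3c[n+]([O-])c5ccccc5c3C4=O)nn2)O1` gives 230 nM in this assay. Compound 3 `O=C1c2c[n+]([O-])c3ccccc3c2C(=O)c2c1c1ccccc1n2Cc1cn([C@@H]2O[C@H](CO)[C@@H](O)[C@H](O)[C@H]2O)nn1` gives 650 nM in this assay, which places it second highest of the three numbers: compound 2 sits nearest, compound 1 furthest, and both gaps lie beyond the scatter.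

The next compound, compound 4 `O=C1c2c[n+]([O-])c3ccccc3c2C(=O)c2c1c1ccccc1n2Cc1cn(C[C@H](O)CO)nn1`, changes compound 3 in one place: 2,3-dihydroxypropyl in place of 3,4,5-trihydroxy-6-(hydroxymethyl)oxan-2-yl on an aromatic nitrogen. Going by the values given here, the only measured step that touches this position is a 2.8-fold higher number from compound 2 to compound 3 (0.45 log units; beyond the scatter), where replacing the (2,2-dimethyl-1,3-dioxolan-4-yl)methyl group by the 3,4,5-trihydroxy-6-(hydroxymethyl)oxan-2-yl group raised the number by a modest amount. Compound 4 now removes that larger ring-bearing group in favour of the short 2,3-dihydroxypropyl chain, so a modest drop back toward the number of compound 2 is expected, though a result within the scatter of compound 3 would not surprise. The expected step is a 1.9-fold lower number from compound 3 to compound 4 (0.27 log units; within the scatter). Compound 4 is therefore estimated at 350 nM in this assay, within a range from 150 nM to 800 nM.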

Compound 4, half-maximal inhibitory concentration: 1310 nM
Compound 4: middle estimate off by 3.7-fold (0.57 log units), on the low side, outside the stated range (above it).
By their numbers in this assay, from the lowest: compound 2; then compounds 3, 4 and 1 (each within the scatter of the next, the first and the last beyond it).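

In this assay, the open 2,3-dihydroxypropyl chain and the 3,4,5-trihydroxy-6-(hydroxymethyl)oxan-2-yl ring cannot be told apart on this aromatic nitrogen, even though the chain has no ring and fewer heavy atoms: the exchange is a 2.0-fold higher number from compound 3 to compound 4 (0.30 log units; within the scatter). The larger change at this position is opening the 2,2-dimethyl-1,3-dioxolan-4-yl group to 1,2-dihydroxyethyl, which is a 5.7-fold higher number from compound 2 to compound 4 (0.76 log units; beyond the scatter), so among these compounds, the clear separation lies between the dimethyl-dioxolane group of compound 2 and the two hydroxyl-bearing groups of compounds 3 and 4. The 1-(2,3-dihydroxypropyl)-1H-1,2,3-triazol-4-yl group, in place of the 5-(4-methylpiperazin-1-yl)pentyl group, gives a 1.8-fold lower number from compound 1 to compound 4 (0.26 log units; within the scatter), so these two quite different side chains also cannot be told apart in this assay.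

No measured evidence on hand explains the separation from compound 2. On these data alone, it also remains open whether an amine, a carboxylic acid or a longer chain carrying a single hydroxyl on this aromatic nitrogen would give a number close to that of compound 2 or close to that of compound 4.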